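Swapping the thiophen-2-yl group of compound 1

This account rests on a few compounds, and the source may have more. Where it says the series, first, only, none or still open, it means among the compounds named here.

For the measured compounds named here, in a functional assay on ileum (Cavia porcellus) for inhibition (on this read-out lower numbers stand for stronger inhibition and higher numbers for weaker inhibition), compound 1 `COC(=O)C1=C(C)NC(C)=C(C(=O)OC)C1c1c(-c2cccs2)nc2sccn12` gives 110 nM, the lowest of the three numbers so far. Compound 2 `COC(=O)C1=C(C)NC(C)=C(C(=O)OC)C1c1c(-c2ccccn2)nc2sc(C)cn12` gives 2810 nM, and compound 3 `COC(=O)C1=C(C)NC(C)=C(C(=O)OC)C1c1c(-c2ccncc2)nc2sc(C)cn12` gives 9690 nM. Compound 4 `COC(=O)C1=C(C)NC(C)=C(C(=O)OC)C1c1c(-c2c(Cl)csc2Cl)nc2sccn12` has not been measured yet. Its structural change is a group of 7 heavy atoms (4 carbon, 1 sulfur, 2 chlorine; one five-membered aromatic ring with 1 hetero atom) in place of a group of 5 heavy atoms (4 carbon, 1 sulfur; one five-membered aromatic ring with 1 hetero atom), on an aromatic carbon, with thiophen-2-yl being the group that leaves. Going by the values given here, only one measured step exchanges one ring group for another, a 3.4-fold higher number from compound 2 to compound 3 (0.54 log units; beyond the scatter), and it is modest but beyond the scatter. It involves different groups, so it is only a rough guide. An upward step of similar modest size is expected, a 2.7-fold higher number from compound 1 to compound 4 (0.44 log units; beyond the scatter). For compound 4 the estimated value is 300 nM, within an expected range of 60 nM to 1500 nM.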

Compound 4, half-maximal inhibitory concentration: 180 nM
Compound 4: the middle estimate sits 1.7-fold (0.22 log units) above what was measured; low and high end bracket the measured number.
By their numbers in this assay, from the lowest: compounds 1 and 4 (each within the scatter of the next); then compound 2; then compound 3.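

The change gives a 1.6-fold higher number from compound 1 to compound 4 (0.21 log units; within the scatter) in this assay, so adding two chlorine atoms to the ring at this position leaves the number indistinguishable from that of compound 1. For the compounds shown here, the only earlier step at this position, between pyridin-2-yl and pyridin-4-yl, exchanged one ring for another; this one shows that a group of 7 heavy atoms can stand here without a change beyond the scatter. Nothing available here explains this result. As far as these compounds go, whether one chlorine alone would behave the same remains open. So does the effect of an amine or a carboxylic acid on this ring.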